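Methoxy in Place of Fluoro on the Benzyl Arm

This account rests on a few compounds, and the source may have more. Where it says the series, first, only, none or still open, it means among the compounds named here.

In a functional assay on NCI-H23 cells (Homo sapiens) for inhibition, read by sulforhodamine B assay, with a stated time of 48 h (a higher number here means that more compound is tolerated, a lower number that less compound is tolerated), compound 3 `Nc1cc(N)c2nc(-c3ccccc3)c(NCc3ccc(F)cc3)nc2c1` stands lowest of the three numbers at 8910 nM; compound 1 `Nc1cc(N)c2nc(-c3ccccc3)c(NCc3ccc(Cl)c(Cl)c3)nc2c1` gives 55000 nM and compound 2 `COc1ccc(CNc2nc3cc(N)cc(N)c3nc2-c2ccccc2)cc1OC` gives 91200 nM. Compound 4 `COc1ccc(CNc2nc3cc(N)cc(N)c3nc2-c2ccccc2)cc1` differs from compound 3 by methoxy in place of fluoro on an aromatic carbon. The step of a 10-fold lower number from compound 2 to compound 3 (1.01 log units; beyond the scatter) bears on this most directly, as it trades methoxy groups for fluoro on the same benzyl arm, and a 6.2-fold lower number from compound 1 to compound 3 (0.79 log units; beyond the scatter) also ends at compound 3 as the lowest point. Running that change in reverse, compound 4 is expected to give a higher number than compound 3, though a single methoxy is estimated to produce a smaller step than a 10-fold lower number from compound 2 to compound 3 (1.01 log units; beyond the scatter). Compound 4 is therefore estimated at 35000 nM with a range of 12000 nM to 100000 nM, an expected step of a 3.9-fold higher number from compound 3 to compound 4 (0.59 log units; beyond the scatter) beyond the scatter.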

Compound 4, concentration lethal to 50% of the cells: 70800 nM
The estimate for compound 4 lay 2.0-fold (0.31 log units) below the measured number, within the range that was stated.
By their numbers in this assay, from the lowest: compound 3; then compounds 1, 4 and 2 (each within the scatter of the next).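

In this assay, methoxy in place of fluoro gives a 7.9-fold higher number from compound 3 to compound 4 (0.90 log units; beyond the scatter), so this one change on the aromatic carbon, para to a large group, is enough to move the number beyond the scatter. A second methoxy adds no readable change, since a 1.3-fold lower number from compound 2 to compound 4 (0.11 log units; within the scatter) lies within the scatter, as does a 1.3-fold higher number from compound 1 to compound 4 (0.11 log units; within the scatter), leaving compound 3 alone apart from the other three. No measurement at hand accounts for this step. The compounds shown leave open whether a hydroxyl, an amine or a lone chloro on that carbon would side with compound 3 or compound 4.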